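Methyl in Place of Fluoro: Expected Shift for Compound 4

The compounds below may be only part of what the source reports. "The series", "measured", "known", "first", "only" and "open" are said of these compounds alone.

Compound 1 `COc1cc(C2CC(c3cc4ccccc4o3)=NN2C(=O)Nc2ccccc2)ccc1O`: 116000000 nM in a functional assay on microsomes from liver (Rattus norvegicus, strain Wistar) for inhibition, with a stated time of 15 min; a lower number here means a stronger inhibitor, a higher number a weaker inhibitor
Compound 2 `COc1cc(C2CC(c3cc4ccccc4o3)=NN2C(=O)Nc2ccc(F)cc2)ccc1O`: 125000000 nM
Compound 3 `COc1ccc(NC(=O)N2N=C(c3cc4ccccc4o3)CC2c2ccc(O)c(OC)c2)cc1`: 29000000 nM

Of the three measured compounds, compound 2 gives the highest number in this assay. Compound 1 lies within the scatter of it, the step of a 1.1-fold higher number from compound 1 to compound 2 (0.03 log units; within the scatter) being negligible, whereas the step of a 4.3-fold lower number from compound 2 to compound 3 (0.63 log units; beyond the scatter) is modest but beyond the scatter.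

Compound 4 `COc1cc(C2CC(c3cc4ccccc4o3)=NN2C(=O)Nc2ccc(C)cc2)ccc1O` differs from compound 2 by methyl in place of fluoro on an aromatic carbon. Among the compounds with values here, two measured steps bear on this change: the exchange of hydrogen for fluoro, a 1.1-fold higher number from compound 1 to compound 2 (0.03 log units; within the scatter), moved nothing, while the exchange of fluoro for methoxy, a 4.3-fold lower number from compound 2 to compound 3 (0.63 log units; beyond the scatter), lowered the number modestly. A methyl group entering at the same place is expected to fall between these two outcomes, giving a small lowering, a 1.6-fold lower number from compound 2 to compound 4 (0.19 log units; within the scatter), that may not clear the scatter. Compound 4 is therefore estimated at 80000000 nM, within a range from 40000000 nM to 160000000 nM.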

Compound 4, half-maximal inhibitory concentration: 44000000 nM
The estimate for compound 4 lay 1.8-fold (0.26 log units) above the measured number; the measured number falls inside the stated range.
By their numbers in this assay, from the lowest: compounds 3 and 4 (each within the scatter of the next); then compounds 1 and 2 (each within the scatter of the next).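

In this assay, methyl at this place clears the scatter where fluoro did not: a 2.8-fold lower number from compound 2 to compound 4 (0.45 log units; beyond the scatter), and a 2.6-fold lower number from compound 1 to compound 4 (0.42 log units; beyond the scatter), against hydrogen. Methoxy is thus not the only group here that lowers the number, and the two cannot be told apart, with a 1.5-fold higher number from compound 3 to compound 4 (0.18 log units; within the scatter). Whether an amine, a carboxylic acid or a longer chain at this place would lower the number further remains open, and nothing in the data given explains why methyl and methoxy lower it while fluoro does not.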